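A few compounds are considered here, and "the series" means these few. Any claim that something is new, unique, unknown or untested is made for them only; others in the source may bear on it.

Compound 1 `COCCOc1nc(N)nc2c1ncn2/C=C1/CC1(CO)CO`: > 20000 nM (a limit)
Compound 2 `CCCCCCCCOc1nc(N)nc2c1ncn2/C=C1/CC1(CO)CO`: > 20000 nM (a limit)

Both entries come from an ADME assay on CCRF-HSB-2 cells (Homo sapiens) for cytotoxicity, with a stated time of 7 days (on this read-out higher numbers stand for lower toxicity in this test and lower numbers for higher toxicity in this test), and neither is an exact number. Going by these compounds, compound 2 stands only at its limit of > 20000 nM, so its true value is unknown. Within the data shown here, the sole measured step is a step that the two limits leave unreadable from compound 1 to compound 2, and it offers no size to carry forward. The evidence amounts to the limit of > 20000 nM in this assay, at which 2 of the 2 values shown sit.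

Compound 3 `CCCSc1nc(N)nc2c1ncn2/C=C1/CC1(CO)CO` is the next analogue: propylsulfanyl in place of octyloxy on an aromatic carbon. In words, propylsulfanyl replaces octyloxy on an aromatic carbon. The measured step changed a chain but kept its oxygen, so it bears only loosely on this swap.

With compound 2 at the limit > 20000 nM, low toxicity is expected to persist. The expected change is a number no higher from compound 2 to compound 3 (the limit leaves the size open), with nothing beyond the scatter foreseen. For compound 3 the estimate is 20000 nM, within a range of 8000 nM to 50000 nM.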

Compound 3, half-maximal cytotoxic concentration: 98000 nM
For compound 3 the middle estimate is 4.9-fold (0.69 log units) below the measured one; measured number outside the range, above it.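

Compound 1 and compound 2 are recorded only as limits, so neither of their steps to compound 3 can be read as a size. The compounds shown leave open whether chain length or the change from oxygen to sulfur affects toxicity on its own.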